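A few compounds are considered here, and "the series" means these few. Any claim that something is new, unique, unknown or untested is made for them only; others in the source may bear on it.

In a functional assay on the whole organism with Mus musculus as the target, in the maximal electroshock model (a lower number here means that less compound is needed, a higher number that more compound is needed for the effect), compound 1 (`O=C1CC(c2ccccc2)(c2ccccc2)C(=O)N1`) gives 107 umol/kg and compound 2 (`CN1C(=O)NC(c2ccccc2)(c2ccccc2)C1=O`) gives 149 umol/kg so the two numbers lie within the scatter of each other. Compound 3 (`CN1C(=O)CC(c2ccccc2)(c2ccccc2)C1=O`) keeps the core of compound 1 and carries methyl in place of hydrogen on an amide-type nitrogen in a ring. Among the measured compounds shown here, no measured pair shows this change on its own, so no step beyond the scatter is expected in this assay in either direction. The expected step is small (a 1.0-fold higher number from compound 1 to compound 3 (0.01 log units; within the scatter)). Compound 3 is estimated at 110 umol/kg with an expected range from 50 umol/kg to 250 umol/kg when measured.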

Compound 3, dose for half-maximal effect: 357 umol/kg
The estimate for compound 3 lay 3.2-fold (0.51 log units) below the measured number; measured number above the stated range.
By their numbers in this assay, from the lowest: compounds 1 and 2 (each within the scatter of the next); then compound 3.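

In this assay, methyl in place of hydrogen on an amide-type nitrogen in a ring proves not to be a neutral change at this position: it gives a 3.3-fold higher number from compound 1 to compound 3 (0.52 log units; beyond the scatter) and so more compound is needed once the amide hydrogen is gone. Among the compounds shown here, no earlier pair showed this change on its own. Nothing available gives a reason for the step. The compounds shown leave open whether a longer chain, such as propyl, or a chain ending in an amine on this nitrogen would raise the number further or bring it back down.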